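From a Bromophenyl to a Dichlorophenyl Arm

The source may report more compounds than this note shows. Statements on the series, on what has been measured and on what is new or still open speak of the compounds shown alone.

Measured compounds:
- compound 1 `COc1ccccc1/C=c1/[nH]c(=O)/c(=C\c2ccccc2OC)[nH]c1=O`: "not active" (no number reported)
- compound 2 `C=CCn1c(=O)/c(=C\c2cccc(Br)c2)[nH]c(=O)/c1=C\c1ccccc1OC`: 5900 nM
- compound 3 `C=CCn1c(=O)/c(=C\c2cc(OC)c(OC)c(OC)c2)[nH]c(=O)/c1=C\c1cccc(Br)c1`: "not active" (no number reported)

The three compounds share a core and differ in the two aromatic arms attached to it. Among the measured compounds shown here, in a functional assay on BGC-823 cells (Homo sapiens) for cytotoxicity, read by CCK-8 assay, with a stated time of 72 h (on this read-out higher numbers stand for weaker inhibition and lower numbers for stronger inhibition), compound 2 gives 5900 nM, and it is the only compound with a number at all: compound 1 and compound 3 are reported simply as not active, so no number can be compared with compound 2. Compound 2 thus stands alone as the one measurable point, without any ranking against the others.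

The next compound, compound 4 `C=CCn1c(=O)/c(=C\c2ccc(Cl)c(Cl)c2)[nH]c(=O)/c1=C\c1ccccc1OC`, keeps the core and the methoxyphenyl arm of compound 2 and alters only the other arm: 3,4-dichlorophenyl in place of 3-bromophenyl on a double-bonded chain carbon bound to an aromatic carbon. Both groups are aromatic carbon rings carrying halogens, with no hydrogen-bond donors or acceptors and no charge, so the exchange is modest in character.

For the measured compounds named here, no step between two measured compounds is available, so the size of the change from compound 2 to compound 4 in this assay cannot be read from the data. The expectation is a step no larger than the scatter, in either direction, a 1.0-fold higher number from compound 2 to compound 4 (0.01 log units; within the scatter). Compound 4 is therefore estimated at 6000 nM, within a range from 2500 nM to 15000 nM.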

Compound 4, half-maximal inhibitory concentration: "not active" (no number reported)
Compound 4 has no reported number here, and the estimate cannot be compared.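

In this assay, among the compounds shown here, compound 4 carries no number, so no step from compound 2 to compound 4 can be read. No measurement at hand bears on this result. The compounds shown leave open how large the gap is between compound 4 and compound 2 at 5900 nM on this read-out.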